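Removing a Methoxy Group from a Weak Serotonin Receptor Ligand

The source may hold more compounds than are shown below. What is called first, only, known or untested is meant among the compounds shown, and "the series" means these compounds.

Measured compounds:
Compound 1 `COc1ccccc1-c1n[nH]cc1N1CCNCC1` gives > 10000 nM in an assay on isolated protein for binding affinity to 5-hydroxytryptamine receptor 3A (Homo sapiens) (a higher number here means a weaker inhibitor, a lower number a stronger inhibitor), a limit of the assay rather than a number.
Compound 2 `COc1ccc(-c2n[nH]cc2N2CCNCC2)cc1` gives > 10000 nM in this assay, again a limit rather than a number.

Compound 2 therefore stands at the limit of what this assay reports, with no measurable affinity. Compound 1 sits at the same limit. Within the data shown here, both values sit at the limit of > 10000 nM in this assay, at which 2 of the 2 values shown sit, so no order between the two compounds can be read, and no step between them is known.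

Compound 3 `c1ccc(-c2n[nH]cc2N2CCNCC2)cc1` differs from compound 2 by hydrogen in place of methoxy on an aromatic carbon. Without any measured step, nothing in these data suggests a change beyond the usual scatter in this assay, in either direction. Compound 3 is therefore expected to remain weak, with an estimated value of 15000 nM (range 4000 nM to 60000 nM). The estimated step from compound 2 to compound 3 is a step that the limit leaves unreadable from compound 2 to compound 3.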

Compound 3, inhibition constant: > 10000 nM
Compound 3 gave a limit, no number; the forecaster's own chance of this, stated with the estimate: 80%; the middle value does not contradict the limit.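

In this assay compound 3 gives > 10000 nM, again a limit rather than a number. No step from compound 1 or compound 2 to compound 3 can be read: the limit of > 10000 nM in this assay, at which 3 of the 3 values shown sit.

As far as these compounds go, how strongly compounds 1, 2 and 3 each bind, and whether hydrogen in place of methoxy changes that at all, stays open.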